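Oxadiazole Exchanged for an Oxime Ether on the Core

A few compounds are considered here, and "the series" means these few. Any claim that something is new, unique, unknown or untested is made for them only; others in the source may bear on it.

Compound 2 `Cc1noc(-c2ccccc2NCC2=NCCN2)n1` carries a 3-methyl-1,2,4-oxadiazol-5-yl group on the shared core. In a functional assay for activation of Alpha-1D adrenergic receptor (Homo sapiens) (a higher number here means that more compound is needed for the effect, a lower number that less compound is needed), compound 2 gives only a limit, < 5020 nM. Compound 1 `c1coc(-c2ccccc2NCC2=NCCN2)c1` gives 16.2 nM in this assay. Among the compounds with values here, the single measured step, a step that the limit leaves unreadable from compound 1 to compound 2, has no readable size because of the limit of < 5020 nM in this assay, at which 1 of the 2 values shown sits. Compound 3 `CCO/N=C(\C)c1ccccc1NCC1=NCCN1` has not been measured; it differs from compound 2 by a group of 6 heavy atoms (4 carbon, 1 nitrogen, 1 oxygen; no ring) in place of a group of 6 heavy atoms (3 carbon, 2 nitrogen, 1 oxygen; one five-membered aromatic ring with 3 hetero atoms), on an aromatic carbon. With no readable step to lean on, the step expected from this change, a step that the limit leaves unreadable from compound 2 to compound 3, is very uncertain. Compound 3 is estimated at 300 nM, expected to fall between 20 nM and 4000 nM.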

Compound 3, half-maximal effective concentration: < 5020 nM
Compound 3 ended at the assay's limit (the forecaster's own chance of this, stated with the estimate: 25%); the middle value lies beyond the limit too.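

The steps from compound 1 to compound 3 and from compound 2 to compound 3 cannot be read, because each rests on a limit of the assay: the limit of < 5020 nM in this assay, at which 2 of the 3 values shown sit. From the compounds shown here alone, whether compound 2 and compound 3 differ from each other in this assay stays open, and so does how far either lies from compound 1.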